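The source may report more compounds than this note shows. Statements on the series, on what has been measured and on what is new or still open speak of the compounds shown alone.

Compound 1 `CCNCc1cc(-c2c(C(=O)NCC)noc2-c2cc(C(C)C)c(O)cc2O)on1` gives 45 nM in a functional assay on HCT-116 cells (Homo sapiens) for inhibition; on this read-out lower numbers stand for stronger inhibition and higher numbers for weaker inhibition; compound 2 `CCNC(=O)c1cc(-c2c(C(=O)NCC)noc2-c2cc(C(C)C)c(O)cc2O)on1` gives 14 nM.

On these numbers compound 1 stands highest of the two, its nearest neighbour being compound 2, reached by a 3.2-fold lower number from compound 1 to compound 2 (0.51 log units; beyond the scatter). Compound 3 `CCNC(=O)c1noc(-c2cc(C(C)C)c(O)cc2O)c1-c1cnn(C)c1` is not yet measured. It differs from compound 1 by 1-methyl-1H-pyrazol-4-yl in place of 3-((ethylamino)methyl)-1,2-oxazol-5-yl on an aromatic carbon, at a ring position next to the ring atom that bears a large group. Among the measured compounds shown here, the only measured step, ethylcarbamoyl in place of (ethylamino)methyl, was modest and touched the same group that now leaves, so it bears only loosely on this larger exchange. A step of roughly similar size, in either direction, is therefore expected: a 1.1-fold lower number from compound 1 to compound 3 (0.05 log units; within the scatter). Compound 3 is estimated at 40 nM, within 10 nM to 160 nM.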

Compound 3, half-maximal inhibitory concentration: 41 nM
Beside the measured number, compound 3's estimate is 1.0-fold (0.01 log units) below it; the measured number falls inside the stated range.
By their numbers in this assay, from the lowest: compound 2; then compounds 3 and 1 (each within the scatter of the next).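

At this position, 1-methyl-1H-pyrazol-4-yl does as well as 3-((ethylamino)methyl)-1,2-oxazol-5-yl in this assay, with a 1.1-fold lower number from compound 1 to compound 3 (0.04 log units; within the scatter), so this ring exchange leaves the read-out unmoved. Set against 3-(ethylcarbamoyl)-1,2-oxazol-5-yl, the same group gives a 2.9-fold higher number from compound 2 to compound 3 (0.47 log units; beyond the scatter), so the position still responds to what it carries. Nothing available accounts for either step. As far as these compounds go, it remains open whether a carboxylic acid or a morpholine on the entering ring would shift the number, and whether a longer chain on the 1,2-oxazole amide would.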